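Side-chain variation in a purine-based oral tail flick series

The source may hold more compounds than are shown below. What is called first, only, known or untested is meant among the compounds shown, and "the series" means these compounds.

Measured compounds:
Compound 1, `NC(=O)CC[C@H](NC(=O)CN(c1ncnc2c1ncn2C1CCCCO1)C1CC1)C(=O)OCc1ccccc1`: 39.4%
Compound 2, `O=C(CN(c1ncnc2c1ncn2C1CCCCO1)C1CC1)NCC(=O)OCc1ccccc1`: 40.4%
Compound 3, `NC(=O)C[C@H](NC(=O)CN(c1ncnc2c1ncn2C1CCCCO1)C1CC1)C(=O)OCc1ccccc1`: 30.5%

All three compounds were tested in a functional assay on the whole organism (Tail, strain ICR) with Mus musculus as the target, in the tail flick test, with a stated time of 60 min, at a dose of 25 umol/kg by the oral route; on this read-out lower numbers stand for a weaker effect and higher numbers for a stronger effect at the one dose given. Compound 3 gives the lowest of the three numbers, but its distance to compound 1, a number 8.9 percentage points lower from compound 1 to compound 3 (within the scatter), and its distance to compound 2, a number 9.9 percentage points lower from compound 2 to compound 3 (within the scatter), both lie within the scatter, so no order among the three can be claimed.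

Compound 4, `CC(C)(C)OC(=O)NCCCC[C@H](NC(=O)CN(c1ncnc2c1ncn2C1CCCCO1)C1CC1)C(=O)OCc1ccccc1`, has not yet been measured. It differs from compound 3 by 3-((tert-butoxycarbonyl)amino)propyl in place of carbamoyl on a saturated chain carbon, two bonds along the chain from an amide-type nitrogen and a carbonyl carbon. The measured steps that bear on this are those in which the side chain at the same place was altered: a number 8.9 percentage points lower from compound 1 to compound 3 (within the scatter), a number 9.9 percentage points lower from compound 2 to compound 3 (within the scatter) and a number 1 percentage points higher from compound 1 to compound 2 (within the scatter). None of them moved the read-out beyond the scatter. The change to compound 4 is larger than any of those, yet nothing in the three compounds indicates a direction. Compound 4 is therefore expected to give 37%, between 22% and 52%, meaning an expected step of a number 6.5 percentage points higher from compound 3 to compound 4 (within the scatter), with no step beyond the scatter expected.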

Compound 4, a percentage reported as activity, at one dose (the size of the read-out at that dose, not a potency): 32.7%
For compound 4 the middle estimate is 4.3 percentage points above the measured one, and the stated range covers the measured number.
By their numbers in this assay, from the lowest: compounds 3, 4, 1 and 2 (each within the scatter of the next).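

Putting 3-((tert-butoxycarbonyl)amino)propyl, with 11 heavy atoms, in place of carbamoyl, with 3, on this saturated chain carbon gave a number 2.2 percentage points higher from compound 3 to compound 4 (within the scatter) in this assay, so even this much larger group leaves the read-out within the scatter. The comparisons with the other two compounds agree, with a number 7.7 percentage points lower from compound 2 to compound 4 (within the scatter) and a number 6.7 percentage points lower from compound 1 to compound 4 (within the scatter), so the carbamoyl side chains, the hydrogen and the protected amino chain are not told apart at this place. No evidence is available that bears on this result.

On these data alone, whether a free amine at the end of this chain, or a carboxylic acid there, would move the read-out beyond the scatter remains open. So does the effect of a longer chain carrying the same tert-butoxycarbonyl amino group.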